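This account rests on a few compounds, and the source may have more. Where it says the series, first, only, none or still open, it means among the compounds named here.

Compound 2 `CCCCCCCCCCCCCCCCCOC(=O)CCC(=O)N1CCN(CCCOc2cc3c(Nc4ccc(F)c(Cl)c4)ncnc3cc2OC)CC1` stands at the top of the two numbers in a functional assay on A549 cells (Homo sapiens) for cytotoxicity, read by MTT assay, with a stated time of 24 h, tested at 80 uM; a lower number here means a stronger effect, a higher number a weaker effect of the compound at the concentration tested: compound 2 gives 83.2%, whereas compound 1 `CCCCCCCCCCOC(=O)CCC(=O)N1CCN(CCCOc2cc3c(Nc4ccc(F)c(Cl)c4)ncnc3cc2OC)CC1` gives 2%. The measured step of a number 81.2 percentage points higher from compound 1 to compound 2 (beyond the scatter) was large. Compound 3 `CCCCCCCCCCCCCCCCCCCCOC(=O)CCC(=O)N1CCN(CCCOc2cc3c(Nc4ccc(F)c(Cl)c4)ncnc3cc2OC)CC1` carries the change (propyl in place of hydrogen on a saturated chain carbon, ten or more bonds along the chain from an oxygen next to a carbonyl group). Among the compounds with values here, this is the same kind of change as the one measured step, which therefore bears directly on it, though it starts from a number already close to the top of the scale. For compound 3 an expected step of a number 4.8 percentage points higher from compound 2 to compound 3 (within the scatter) follows. Compound 3 is accordingly estimated at 88%, in the range 65% to 100%.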

Compound 3, a percentage reported as activity, at one concentration (the size of the read-out at that concentration, not a potency): 85.2%
Estimate against measurement, compound 3: 2.8 percentage points above, within the range that was stated.
By their numbers in this assay, from the lowest: compound 1; then compounds 2 and 3 (each within the scatter of the next).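

In this assay, adding propyl to the chain of compound 2 gives a number 2 percentage points higher from compound 2 to compound 3 (within the scatter), so this further extension cannot be told apart from the scatter. Adding decyl to the chain of compound 1 gives a number 83.2 percentage points higher from compound 1 to compound 3 (beyond the scatter), so the large effect of chain extension at this place is not carried further by the last addition. Nothing shown here gives a cause for this.

Open, from the compounds shown here alone, is how the number behaves at chain lengths between those of compound 1 and compound 2. Also open, going by these compounds, is whether a longer chain, an amine or a carboxylic acid would change it.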